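Swapping the Amide for a Thioester on a Shared Core

This account rests on a few compounds, and the source may have more. Where it says the series, first, only, none or still open, it means among the compounds named here.

Compound 1, `CC1=C(C(=O)OCC(C)C)C(c2ccoc2)NC(=O)N1`: 16%
Compound 2, `CC1=C(C(=O)OC(C)(C)C)C(c2ccoc2)NC(=O)N1`: 2%
Compound 3, `CCN(CC)C(=O)C1=C(C)NC(=O)NC1c1ccoc1`: 37%

These three compounds share one core and differ only in the group on the carbonyl carbon. In an assay on membranes from HeLa cells for displacement of a labelled ligand from adenosine receptor A3 (Homo sapiens), read by scintillation counting, with a stated time of 180 min, tested at 1 uM (a higher number here means more inhibition at the concentration tested (going by the name of the read-out), a lower number less inhibition), compound 3 stands highest of the three: the step of a number 21 percentage points higher from compound 1 to compound 3 (beyond the scatter) is modest and the step of a number 35 percentage points higher from compound 2 to compound 3 (beyond the scatter) is large, so both the isobutoxy and the tert-butoxy compounds lie well below the diethylamino one. Compound 4, `CC1=C(C(=O)SC(C)C)C(c2ccoc2)NC(=O)N1`, carries the change (isopropylsulfanyl in place of diethylamino on a carbonyl carbon). Both measured steps moved toward diethylamino and raised the number, so moving away from diethylamino is expected to lower it, probably to the level of the esters. For compound 4 the expected step is a number 25 percentage points lower from compound 3 to compound 4 (beyond the scatter), giving an estimate of 12% with a range from 0% to 30%.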

Compound 4, a percentage reported as inhibition, at one concentration (the size of the read-out at that concentration, not a potency): 3%
For compound 4 the middle estimate is 9 percentage points above the measured one, and the stated range covers the measured number.
By their numbers in this assay, from the lowest: compounds 2 and 4 (each within the scatter of the next); then compound 1; then compound 3.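

In this assay, isopropylsulfanyl does not keep the level reached with diethylamino, a number 34 percentage points lower from compound 3 to compound 4 (beyond the scatter), so a sulfur-linked group at this carbonyl carbon reads like the esters rather than the amide. Among the esters it sits with the tert-butoxy compound, a number 1 percentage points higher from compound 2 to compound 4 (within the scatter), but under the isobutoxy one, a number 13 percentage points lower from compound 1 to compound 4 (beyond the scatter). Nothing available here explains these differences. The compounds shown leave open how a dimethylamino group, a pyrrolidine amide or a free carboxylic acid would read on this carbonyl carbon.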